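The source may report more compounds than this note shows. Statements on the series, on what has been measured and on what is new or still open speak of the compounds shown alone.

Values in a functional assay on MCF7 cells (Homo sapiens) for inhibition, read by MTT assay, with a stated time of 72 h; a higher number here means a weaker inhibitor, a lower number a stronger inhibitor:

compound 1 `Cc1ccc(CSc2nc3nc(C)cc(Nc4cc(-c5ccccc5)[nH]n4)n3n2)cc1`: 7290 nM
compound 2 `Cc1cc(Nc2cc(-c3ccccc3)[nH]n2)n2nc(SCc3ccc(C(F)(F)F)cc3)nc2n1`: 4820 nM
compound 3 `Cc1ccc(Cn2ccc(Nc3cc(C)nc4nc(SCc5ccc(Br)cc5)nn34)n2)cc1`: 11300 nM

Compound 1 and compound 2 share one core and differ in one place, (trifluoromethyl in place of methyl on an aromatic carbon). The step that this change made is a 1.5-fold lower number from compound 1 to compound 2 (0.18 log units; within the scatter). Compound 3 carries a different core; the difference between the core of compound 1 and the core of compound 3 is not broken down here. Against compound 1 the number for compound 3 lies within the scatter; against compound 2 it lies beyond the scatter.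

Compound 4 `Cc1cc(Nc2ccn(Cc3ccc(C(F)(F)F)cc3)n2)n2nc(SCc3ccc(Br)cc3)nc2n1` has not yet been measured. It differs from compound 3 as trifluoromethyl in place of methyl on an aromatic carbon, the same change as from compound 1 to compound 2, at the same place on the same kind of ring. Among the measured compounds shown here, the one measured step of this change was within the scatter. On that basis compound 4 is expected to show a step of similar size, a 1.4-fold lower number from compound 3 to compound 4 (0.16 log units; within the scatter). The expectation rests on a single pair on a different core, so the range is kept wide. In this assay compound 4 is estimated at 7800 nM, between 3500 nM and 16000 nM.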

Compound 4, half-maximal inhibitory concentration: 2280 nM
Beside the measured number, compound 4's estimate is 3.4-fold (0.53 log units) above it; the measured number lies below the stated range.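

In this assay the replacement of methyl by trifluoromethyl on the core of compound 3 gives a 5.0-fold lower number from compound 3 to compound 4 (0.70 log units; beyond the scatter) and so lies beyond the scatter. The size of the step did not carry over from the core of compound 1 to the core of compound 3: the same change on two cores in this assay, a 1.5-fold lower number (0.18 log units; within the scatter) from compound 1 to compound 2 and a 5.0-fold lower number (0.70 log units; beyond the scatter) from compound 3 to compound 4, 3.3-fold (0.52 log units) apart, beyond the scatter of two such steps

Only the step on the core of compound 3 lies beyond the scatter, so no shared direction can be claimed, and with one pair per core nothing is shown about which part of the two cores goes with the different sizes or how the change would behave on a third core.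

Still open, as far as these compounds go, is whether other groups in place of the 4-(trifluoromethyl)phenyl substituent, such as a nitrile, a methoxy group or a carboxylic acid, would follow compound 4 on the core of compound 3. Also open, from the compounds shown here alone, is how an amine in place of the bromine on the other benzyl group would affect the number.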